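Replacing amino with methyl on a weakly active nucleoside

The source may report more compounds than this note shows. Statements on the series, on what has been measured and on what is new or still open speak of the compounds shown alone.

Compound 3 `Nc1nc(N)c2c(-c3cc4ccccc4o3)cn([C@@H]3O[C@H](CO)[C@@H](O)[C@H]3O)c2n1` is one of three measured nucleosides sharing the same core. In a functional assay on CEM-DNR-bulk cells (Homo sapiens), read by MTT assay, with a stated time of 72 h (on this read-out higher numbers stand for weaker inhibition and lower numbers for stronger inhibition), compound 3 gives > 20000 nM, which is a limit of the assay rather than a number. Compound 1 `Nc1nc(N)c2c(-c3ccsc3)cn([C@@H]3O[C@H](CO)[C@@H](O)[C@H]3O)c2n1` in this assay gives > 20000 nM, likewise a limit. Compound 2 `COc1nc(N)nc2c1c(-c1cc3ccccc3o1)cn2[C@@H]1O[C@H](CO)[C@@H](O)[C@H]1O` in this assay gives 16700 nM. The step that the two limits leave unreadable from compound 1 to compound 3 therefore cannot be read, and the step of an at least 1.1-fold higher number from compound 2 to compound 3 (0.07 log units; that floor lies within the scatter) stays within the scatter; the measured values cluster around (the limit of > 20000 nM in this assay, at which 2 of the 3 values shown sit), so compound 3 stands at the weak end of what this assay can report.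

Compound 4 `Cc1nc(N)c2c(-c3cc4ccccc4o3)cn([C@@H]3O[C@H](CO)[C@@H](O)[C@H]3O)c2n1` differs from compound 3 by methyl in place of amino on an aromatic carbon. Among the measured compounds shown here, no measured step changes this same group, so the only guide is the general weakness of all three compounds. Compound 4 is expected to give 25000 nM, within 8000 nM to 80000 nM. The expected step is a step that the limit leaves unreadable from compound 3 to compound 4, which amounts to no change beyond the scatter.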

Compound 4, half-maximal inhibitory concentration: 6310 nM
Beside the measured number, compound 4's estimate is 4.0-fold (0.60 log units) above it; the measured number lies below the stated range.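

In this assay methyl in place of amino on this aromatic carbon, which lies between two ring nitrogen atoms, gives an at least 3.1-fold lower number from compound 3 to compound 4 (0.50 log units; beyond the scatter) and is the only step shown that can be read as beyond the scatter. Among the compounds shown here, the other steps either cannot be read or have a floor within the scatter, so the earlier compounds did not show that this carbon can move the read-out. The change is small, one heavy atom for one heavy atom, with the hydrogen-bond donor and acceptor counted for amino absent from methyl.

The compounds shown leave open what an ethyl group or a chlorine atom would give at this place, and whether methyl gives a similar step with thiophen-3-yl in place of 1-benzofuran-2-yl. The full size of the step also stays open, because compound 3 gives only a limit and not a number: the limit of > 20000 nM in this assay, at which 2 of the 4 values shown sit.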